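Lysine to leucine side chain in a purine glycinamide series

The source may report more compounds than this note shows. Statements on the series, on what has been measured and on what is new or still open speak of the compounds shown alone.

Two members of this series have numbers in a functional assay on the whole organism (Tail, strain ICR) with Mus musculus as the target, in the tail flick test, with a stated time of 150 min, at a dose of 6.25 umol/kg by the oral route; a lower number here means a weaker effect, a higher number a stronger effect of the compound at the dose given. Compound 1 `N=C(N)NCCC[C@H](NC(=O)CN(c1nc(Cl)nc2[nH]cnc12)C1CC1)C(=O)O` gives 5.09% in this assay, and compound 2 `NCCCC[C@H](NC(=O)CN(c1nc(Cl)nc2[nH]cnc12)C1CC1)C(=O)O` gives 2.82%. Among the measured compounds shown here, the two numbers sit within the usual scatter of each other; the one step between them, a number 2.3 percentage points lower from compound 1 to compound 2 (within the scatter), is a change of a group on a saturated chain carbon four bonds along the chain from an amide-type nitrogen and a carbonyl carbon, and nothing beyond the scatter follows from it. Compound 2 is therefore not set apart from compound 1 by the data.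

Compound 3 `CC(C)C[C@H](NC(=O)CN(c1nc(Cl)nc2[nH]cnc12)C1CC1)C(=O)O` differs from compound 2 by isopropyl in place of 3-aminopropyl on a saturated chain carbon, two bonds along the chain from an amide-type nitrogen and a carbonyl carbon. For the measured compounds named here, no measured step involves isopropyl, and the only step known, from compound 1 to compound 2, stayed within the scatter. The expectation for this assay is thus a step from compound 2 to compound 3 of no size beyond the scatter, written as a number 1.2 percentage points higher from compound 2 to compound 3 (within the scatter). Compound 3 is estimated at 4% in this assay, with a range from 0% to 14%.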

Compound 3, a percentage reported as activity, at one dose (the size of the read-out at that dose, not a potency): 5.56%
Beside the measured number, compound 3's estimate is 1.6 percentage points below it, and the stated range covers the measured number.
By their numbers in this assay, from the lowest: compounds 2, 1 and 3 (each within the scatter of the next).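

In this assay, isopropyl in place of 3-aminopropyl on a saturated chain carbon, two bonds along the chain from an amide-type nitrogen and a carbonyl carbon, gives a number 2.7 percentage points higher from compound 2 to compound 3 (within the scatter), and the replacement of the larger group of compound 1 by the same isopropyl gives a number 0.5 percentage points higher from compound 1 to compound 3 (within the scatter). The earlier step compared two nitrogen-bearing groups only; compound 3 adds an all-carbon group with 0 hydrogen-bond donors and 0 hydrogen-bond acceptors, and across compounds 1, 2 and 3 the read-out at this single dose does not separate the three groups, so a side-chain nitrogen at this place is not required for a number within this range. No measured information is available to account for this outcome.

Going by these compounds, whether a benzyl group or a side-chain carboxylic acid at this place would give a step beyond the scatter stays open. Also open, on these data alone, is whether replacing the cyclopropyl group on the nitrogen of the shared core, or converting the terminal carboxylic acid to its methyl ester, would change this assay by more than the side chains have so far.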